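Chloro in place of hydrogen on the 4-methoxyphenyl of compound 3

The source may report more compounds than this note shows. Statements on the series, on what has been measured and on what is new or still open speak of the compounds shown alone.

In an ADME assay on MIA PaCa-2 cells (Homo sapiens) for cytotoxicity, read by MTT assay, with a stated time of 72 h (a higher number here means a weaker inhibitor, a lower number a stronger inhibitor), compound 3 `COc1ccc(C2=C(c3cc(OC)c(OC)c(OC)c3)C(=O)C(O)C2)cc1` gives < 1 ug/mL, which is a limit of the assay, not a number (the limit of < 1 ug/mL in this assay, at which 1 of the 3 values shown sits). Compound 2 `C=CCOc1cc(C2=C(c3cc(OC)c(OC)c(OC)c3)C(=O)C(O)C2)ccc1OC` gives > 100 ug/mL, again only a limit (the limit of > 100 ug/mL in this assay, at which 1 of the 3 values shown sits). Going by the values given here, the one measured step in a single place, an at least 100-fold lower number from compound 2 to compound 3 (2.00 log units; beyond the scatter), concerns the same ring, hydrogen in place of allyloxy on an aromatic carbon. Compound 1 `COc1ccc(C2=C(c3cc(OC)c(OC)c(OC)c3)C(=O)C(OC(C)=O)C2)cc1Cl`, an acetate already carrying chloro, gives 24 ug/mL. Compound 4 `COc1ccc(C2=C(c3cc(OC)c(OC)c(OC)c3)C(=O)C(O)C2)cc1Cl` differs from compound 3 by chloro in place of hydrogen on an aromatic carbon. Among the compounds with values here, no measured step isolates this change, and since compound 3 sits at a limit only a flat or weaker outcome can be read. The value expected for compound 4 is 4 ug/mL, between 0.8 ug/mL and 25 ug/mL. The estimate implies a step of an at least 4.0-fold higher number from compound 3 to compound 4 (0.60 log units; beyond the scatter).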

Compound 4, half-maximal inhibitory concentration: > 100 ug/mL
Compound 4: no number, only a limit; the forecaster's own chance of this, stated with the estimate: 20%; at least 25-fold (1.39 log units) between middle value and limit.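

In this assay, the change from 4-methoxyphenyl to 3-chloro-4-methoxyphenyl gives an at least 100-fold higher number from compound 3 to compound 4 (2.00 log units; beyond the scatter), so chloro ortho to the methoxy group is a large loss on this ring. Compound 4 gives > 100 ug/mL, which is a limit of the assay and not a number. With chloro present, the free hydroxyl does not restore activity, as hydrogen in place of acetyl gives an at least 4.1-fold higher number from compound 1 to compound 4 (0.61 log units; beyond the scatter).

The step from compound 2 to compound 4 cannot be read, as both values are limits. As far as these compounds go, whether fluoro or an amine at this position would keep the activity of compound 3 remains open.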